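Tolerability notes on the shared core, compound 4 pending

The compounds below may be only part of what the source reports. "The series", "measured", "known", "first", "only" and "open" are said of these compounds alone.

Compound 1 `COc1ccc([C@H]2CC(=O)N(Cc3cccc(N)c3)C2)cc1OC1CCCC1` gives in a functional assay on HEK293 cells (Homo sapiens) for cytotoxicity; a higher number here means that more compound is tolerated, a lower number that less compound is tolerated > 10000 nM, a limit of the assay.
Compound 2 `COc1ccc([C@H]2CC(=O)N(c3ccc(N)cc3)C2)cc1OC1CCCC1` gives in this assay > 10000 nM, again a limit.
Compound 3 `COc1ccc([C@H]2CC(=O)N(c3cc(N)cc(F)c3)C2)cc1OC1CCCC1` gives in this assay > 10000 nM, a limit as well.

Compound 2 therefore stands where every other measured member of the series stands: at the limit, with no numerical value for it (the limit of > 10000 nM in this assay, at which 3 of the 3 values shown sit). Compound 4 `COc1ccc([C@H]2CC(=O)N(c3ccc(S(C)(=O)=O)cc3)C2)cc1OC1CCCC1` differs from compound 2 by methylsulfonyl in place of amino on an aromatic carbon.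

The measured steps that bear on this change all run between substituents on the same amide-type nitrogen in a ring: a step that the two limits leave unreadable from compound 1 to compound 2, a step that the two limits leave unreadable from compound 2 to compound 3 and a step that the two limits leave unreadable from compound 1 to compound 3. None of them yields a readable size, and none of them involves a methylsulfonyl. Among the compounds with values here, no measured step therefore tells whether exchanging amino for methylsulfonyl on the aromatic carbon moves tolerated concentration at all.

With every recorded value sitting at the limit (the limit of > 10000 nM in this assay, at which 3 of the 3 values shown sit), the expectation for compound 4 is that it too stays at or near that limit, a step that the limit leaves unreadable from compound 2 to compound 4 in this assay. Compound 4 is estimated at 15000 nM, with a range from 5000 nM to 50000 nM, and the result is most likely to be reported as a limit.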

Compound 4, half-maximal cytotoxic concentration: > 10000 nM
Compound 4 was reported as a limit; the forecaster's own chance of this, stated with the estimate: 80%; the middle value does not contradict the limit.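

In this assay compound 4 gives > 10000 nM, again a limit. No step linking compound 4 to compound 1, compound 2 or compound 3 can be read: the limit of > 10000 nM in this assay, at which 4 of the 4 values shown sit.

The compounds shown leave open at what concentration any of them stops being tolerated, and whether the substituents on the ring nitrogen differ in this respect at all.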